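Amide to urea on a pyrazole scaffold: expected potency shift

The source may report more compounds than this note shows. Statements on the series, on what has been measured and on what is new or still open speak of the compounds shown alone.

Compounds measured so far:
- compound 1, `COc1cc(-c2nn(-c3cccc(NC(=O)Nc4cc(C(F)(F)F)cc(C(F)(F)F)c4)c3)cc2-c2ccncc2)ccc1Cl`: 140 nM
- compound 2, `COc1cc(-c2nn(-c3cccc(NC(=O)c4cccc(C(F)(F)F)c4)c3)cc2-c2ccncc2)ccc1Cl`: 560 nM
- compound 3, `O=C(Nc1cccc(-n2cc(-c3ccncc3)c(-c3ccc(Cl)c(O)c3)n2)c1)Nc1ccc(Cl)c(Cl)c1`: 680 nM

All three compounds were tested in a functional assay on HOP-92 cells (Homo sapiens) for inhibition, read by sulforhodamine B assay, with a stated time of 48 h; on this read-out higher numbers stand for weaker inhibition and lower numbers for stronger inhibition. Among the three numbers, compound 2 stands second highest. Its nearest neighbour is compound 3, whose value lies within the usual scatter of compound 2, so the two cannot be told apart. Its furthest neighbour is compound 1, which gives a clearly lower number, a gap that lies beyond the scatter.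

Compound 4, `COc1cc(-c2nn(-c3cccc(NC(=O)Nc4cccc(C(F)(F)F)c4)c3)cc2-c2ccncc2)ccc1Cl`, has not yet been measured in this assay. It differs from compound 2 in one place: (3-(trifluoromethyl)phenyl)amino in place of 3-(trifluoromethyl)phenyl on a carbonyl carbon. In plain words, the amide of compound 2 becomes a urea in compound 4, while the rest of the molecule is kept.

Among the measured compounds shown here, no step between two measured compounds isolates exactly this change. Still, compound 1 is the only urea among the measured compounds and it gives 140 nM, the lowest number of the set. On that basis the account expects the step from compound 2 to compound 4 in this assay to go downward, by an amount estimated at a 2.2-fold lower number from compound 2 to compound 4 (0.33 log units; beyond the scatter), which would be beyond the scatter. The estimate for compound 4 is therefore 260 nM, with a range from 110 nM to 650 nM, because compound 1 gives 140 nM.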

Compound 4, half-maximal inhibitory concentration: 560 nM
Compound 4: the middle estimate sits 2.2-fold (0.33 log units) below what was measured, within the range that was stated.
By their numbers in this assay, from the lowest: compound 1; then compounds 2, 4 and 3 (each within the scatter of the next).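

In this assay, (3-(trifluoromethyl)phenyl)amino in place of 3-(trifluoromethyl)phenyl on a carbonyl carbon gives no change at the digits printed from compound 2 to compound 4 (within the scatter), so with this aryl group the urea and the amide cannot be told apart. The pair of ureas shows a different change making the difference: hydrogen in place of trifluoromethyl on an aromatic carbon gives a 4.0-fold higher number from compound 1 to compound 4 (0.60 log units; beyond the scatter), so in this pair the lower number of compound 1 goes with its extra trifluoromethyl and not with the urea alone. Nothing available here accounts for why one change leaves the number in place while the other moves it.

Among the compounds shown here, it remains open whether the amide and the urea would also stay level with the aryl group of compound 1, as the one comparison of the two linkers rests on a single aryl group. From the compounds shown here alone, it is also open whether a nitrile, a carboxylic acid or a dimethylamino group on that aromatic carbon would give a number closer to that of compound 1 or of compound 4.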